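Sulfonamide nitrogen substituent: from compound 2 to compound 3

The source may hold more compounds than are shown below. What is called first, only, known or untested is meant among the compounds shown, and "the series" means these compounds.

In a functional assay (CEM-VLB cells, Homo sapiens) for antiproliferative activity, read by sulforhodamine B assay, with a stated time of 48 h (a lower number here means a stronger inhibitor, a higher number a weaker inhibitor), compound 1 `CCc1cccc(NS(=O)(=O)c2ccc(N3CCNC3=O)cc2)c1` gives 450 nM and compound 2 `Cc1cc(C)cc(NS(=O)(=O)c2ccc(N3CCNC3=O)cc2)c1` gives 400 nM. For the measured compounds named here, these two numbers lie within the scatter of each other, and compound 2 therefore stands level with the only other measured compound. Still unmeasured, compound 3 `O=C1NCCN1c1ccc(S(=O)(=O)Nc2cccc(Cl)c2)cc1` carries 3-chlorophenyl in place of 3,5-dimethylphenyl on a sulfonamide nitrogen.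

Going by the values given here, one measured step bears on this change: a 1.1-fold lower number from compound 1 to compound 2 (0.05 log units; within the scatter). It exchanges 3-ethylphenyl for 3,5-dimethylphenyl at the same place and stays within the scatter. Among the compounds with values here, no measured compound carries chlorine, and a single step sets no direction. It is a limited guide, but no step beyond the scatter is expected in this assay. The estimated change is a 1.1-fold higher number from compound 2 to compound 3 (0.05 log units; within the scatter). For compound 3 the estimated value is 450 nM, with an expected range of 180 nM to 1100 nM.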

Compound 3, half-maximal inhibitory concentration: 170 nM
The estimate for compound 3 lay 2.6-fold (0.42 log units) above the measured number, outside the stated range (below it).
By their numbers in this assay, from the lowest: compound 3; then compounds 2 and 1 (each within the scatter of the next).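

In this assay the aryl group on the sulfonamide nitrogen proves able to move the number beyond the scatter: 3-chlorophenyl in place of 3,5-dimethylphenyl gives a 2.4-fold lower number from compound 2 to compound 3 (0.37 log units; beyond the scatter) and so makes compound 3 the strongest inhibitor of the three, whereas the two alkyl-bearing aryl groups had stood level. Chloro in place of ethyl on an aromatic carbon points the same way with a 2.6-fold lower number from compound 1 to compound 3 (0.42 log units; beyond the scatter) and this is the cleaner comparison, as the exchange there touches one group only, so the modest shift is seen against both alkyl-bearing partners rather than against one. Nothing available explains the shift, and no cause can be assigned to the chlorine on these data.

Whether the effect belongs to chloro alone or extends to other groups on that aromatic carbon stays open, with bromo, fluoro, methoxy and nitrile absent from the compounds shown. Equally open, going by these compounds, is how far this position accepts an amine or a carboxylic acid on the aryl group, or a longer chain in place of the aryl group on the sulfonamide nitrogen.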